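A few compounds are considered here, and "the series" means these few. Any claim that something is new, unique, unknown or untested is made for them only; others in the source may bear on it.

Measured so far in an assay on isolated protein for inhibition of ribosomal protein S6 kinase alpha-1 (Homo sapiens), read by mobility shift assay, tested at 30 uM; on this read-out higher numbers stand for more inhibition at the one concentration tested (going by the name of the read-out) and lower numbers for less inhibition:
compound 1 `COc1ccc(-c2c(C)[nH]c(=O)c3c(N)nn(C)c23)cc1` gives 18%
compound 2 `Nc1c2c(=O)[nH]c(-c3ccccc3)cc2nn1-c1ccccn1` gives 5%
compound 3 `Cc1cc2nc(N)nc(N)c2c(=O)[nH]1` gives -4%

Compound 3 stands lowest of the three numbers in this assay. Its nearest neighbour is compound 2, whose number lies within the scatter of it; the furthest is compound 1, whose number lies beyond the scatter. For the measured compounds named here, no pair among the measured compounds differs in only one place, so no single step is known.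

Compound 4 `Cc1cc2nc(-c3ccccc3)nc(N)c2c(=O)[nH]1` differs from compound 3 by phenyl in place of amino on an aromatic carbon. Compound 1 and compound 2 both carry an aromatic carbon ring and give the two higher numbers, which suggests a modest upward step. The expected step of a number 12 percentage points higher from compound 3 to compound 4 (beyond the scatter) is small, at the edge of the scatter. Compound 4 is expected to give about 8% in this assay, in the range -8% to 25%.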

Compound 4, a percentage reported as inhibition, at one concentration (the size of the read-out at that concentration, not a potency): 14%
For compound 4 the middle estimate is 6 percentage points below the measured one; the measured number falls inside the stated range.
By their numbers in this assay, from the lowest: compounds 3, 2, 4 and 1 (each within the scatter of the next, the first and the last beyond it).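

In this assay, for the compounds shown here, phenyl in place of amino on the aromatic carbon between two ring nitrogen atoms gives a number 18 percentage points higher from compound 3 to compound 4 (beyond the scatter), the only single change read so far. This position therefore accepts a six-membered aromatic ring of carbon only, and the number does not fall when the amino group leaves. Nothing at hand explains this step. From the compounds shown here alone, whether the rise needs the aromatic ring itself, or follows from the loss of the amino group alone, stays open, as does what a methyl group, a cyclohexyl ring or a morpholine would give on this carbon.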